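Phenyl in Place of Methoxy: Expecting a Modest Shift

The compounds below may be only part of what the source reports. "The series", "measured", "known", "first", "only" and "open" are said of these compounds alone.

Within the data shown here, compound 2 `COc1ccc(-c2csc(Nc3cc4[nH]c(=O)cnc4cc3N(C)C3CCCCC3)n2)cc1` gives 15000 nM in an ADME assay on Huh-7 cells (Homo sapiens) for cytotoxicity (a higher number here means a weaker inhibitor, a lower number a stronger inhibitor), the lowest of the two numbers measured so far; compound 1 `CN(c1cc2ncc(=O)[nH]c2cc1Nc1nc(-c2ccccc2)cs1)C1CCCCC1` gives 62500 nM. Compound 3 `CN(c1cc2ncc(=O)[nH]c2cc1Nc1nc(-c2ccc(-c3ccccc3)cc2)cs1)C1CCCCC1` has not yet been measured. It differs from compound 2 in one way: phenyl in place of methoxy on an aromatic carbon. Among the measured compounds shown here, the only step measured, a 4.2-fold lower number from compound 1 to compound 2 (0.62 log units; beyond the scatter), concerned methoxy entering on that same aromatic carbon; no step measures phenyl there, so the bearing is indirect. A step of about a 1.9-fold lower number from compound 2 to compound 3 (0.27 log units; within the scatter) is therefore expected, downward but modest. Compound 3 is estimated at 8000 nM, within a range of 2000 nM to 30000 nM.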

Compound 3, half-maximal inhibitory concentration: 82000 nM
Beside the measured number, compound 3's estimate is 10-fold (1.01 log units) below it, and the stated range ends below it.
By their numbers in this assay, from the lowest: compound 2; then compounds 1 and 3 (each within the scatter of the next).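

At this aromatic carbon, phenyl in place of methoxy gives a 5.5-fold higher number from compound 2 to compound 3 (0.74 log units; beyond the scatter) in this assay, so the lower number seen with methoxy does not simply carry over to a bigger group. Phenyl in place of hydrogen gives a 1.3-fold higher number from compound 1 to compound 3 (0.12 log units; within the scatter) and so no real change, which makes the effect at this position depend on the group placed there. Nothing measured here explains why methoxy and phenyl differ.

As far as these compounds go, whether an amine or a carboxylic acid on this carbon would follow methoxy or phenyl stays open.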